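The source may hold more compounds than are shown below. What is called first, only, known or untested is meant among the compounds shown, and "the series" means these compounds.

In a functional assay on A549 cells (Homo sapiens) for inhibition, read by MTT assay, with a stated time of 48 h (a lower number here means a stronger inhibitor, a higher number a weaker inhibitor), compound 1 `Cc1ccc(OCc2cn(-c3ccc(NS(C)(=O)=O)c(Oc4ccccc4)c3)nn2)cc1` gives 8000 nM. Compound 3 `Cc1cc(OCc2cn(-c3ccc(NS(C)(=O)=O)c(Oc4ccccc4)c3)nn2)ccc1Cl` gives 6700 nM, so it stands level with compound 1 once the scatter is allowed for. For compound 2 `CS(=O)(=O)Nc1ccc(-n2cc(OCc3ccccc3)nn2)cc1Oc1ccccc1` the entry reads "not determined" (no result reported), so it offers no comparison.

The next compound, compound 4 `CS(=O)(=O)Nc1ccc(-n2cc(COc3ccc(Cl)cc3)nn2)cc1Oc1ccccc1`, departs from compound 3 by a single change: hydrogen in place of methyl on an aromatic carbon. Hydrogen takes the place of methyl on an aromatic carbon, ortho to a chloro group and meta to a large group, so that 4-chlorophenyl replaces 4-chloro-3-methylphenyl.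

Among the compounds with values here, only one measured step bears on this, and only indirectly. The step of a 1.2-fold lower number from compound 1 to compound 3 (0.08 log units; within the scatter) replaces 4-methylphenyl with 4-chloro-3-methylphenyl, and it stays within the scatter. Within the data shown here, that step alters the same aromatic ring but is not the same change, and no measured pair isolates the methyl group alone. The data therefore give no reason to expect a shift in either direction in this assay, although they constrain the question only weakly.

The expected step is a 1.1-fold higher number from compound 3 to compound 4 (0.05 log units; within the scatter), which would not stand beyond the scatter. Compound 4 is estimated at 7500 nM, with an expected range of 3500 nM to 16000 nM.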

Compound 4, half-maximal inhibitory concentration: 7100 nM
Beside the measured number, compound 4's estimate is 1.1-fold (0.02 log units) above it, within the range that was stated.
By their numbers in this assay, from the lowest: compounds 3, 4 and 1 (each within the scatter of the next).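

Within the data shown here, with the step of a 1.1-fold higher number from compound 3 to compound 4 (0.03 log units; within the scatter) in this assay, the methyl group on the aromatic carbon ortho to a chloro group is isolated for the first time, and hydrogen in its place leaves the two compounds level. The earlier pair changed that ring in two places at once, whereas the step of a 1.1-fold lower number from compound 1 to compound 4 (0.05 log units; within the scatter) now gives a separate reading for chloro in place of methyl on an aromatic carbon, and that exchange also stays within the scatter, so 4-methylphenyl, 4-chlorophenyl and 4-chloro-3-methylphenyl cannot be told apart in this series. Nothing measured here accounts for this level reading.

The compounds shown leave open whether an amine or a carboxylic acid on either of these aromatic carbons would give a number beyond the scatter. They also leave open whether a longer chain in place of the methylene link in the (4-chlorophenoxy)methyl group would do so, and compound 2 still offers no comparison on that part of the molecule.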